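The compounds below may be only part of what the source reports. "The series", "measured", "known", "first", "only" and "open" are said of these compounds alone.

Compound 1 `CCOC(=O)C1=Cc2ccccc2OC1(OCc1cn(-c2ccc(F)cc2)nn1)C(F)(F)F`: 8900 nM
Compound 2 `CCOC(=O)C1=Cc2ccccc2OC1(OCc1cc(-c2ccc(OC)cc2)no1)C(F)(F)F`: > 150000 nM

Of the compounds shown here, two sharing one core have been tested in a functional assay on DU-145 cells (Homo sapiens) for inhibition, read by MTT assay, with a stated time of 24 h; on this read-out lower numbers stand for stronger inhibition and higher numbers for weaker inhibition. Compound 1 `CCOC(=O)C1=Cc2ccccc2OC1(OCc1cn(-c2ccc(F)cc2)nn1)C(F)(F)F` gives 8900 nM in this assay. Compound 2 `CCOC(=O)C1=Cc2ccccc2OC1(OCc1cc(-c2ccc(OC)cc2)no1)C(F)(F)F` returns only a limit in this assay, > 150000 nM, and no number. Among the measured compounds shown here, compound 1 therefore stands as the only compound with a measured number; the other value shown is a limit, namely (the limit of > 150000 nM in this assay, at which 1 of the 2 values shown sits).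

For the measured compounds named here, no step between two measured compounds is available, so the size of any change can only be anticipated. The compound not yet measured, compound 3 `CCOC(=O)C1=Cc2ccccc2OC1(OCc1cn(CC(=O)Nc2ccc(OC)cc2)nn1)C(F)(F)F`, differs from compound 1 in one place: ((4-methoxyphenyl)carbamoyl)methyl in place of 4-fluorophenyl on an aromatic nitrogen. Going by the values given here, since no measured pair shows the effect of a change at this aromatic nitrogen, the direction is open; a step in this assay of the order seen between the compound with a number and the one at the limit cannot be ruled out, but a shift of modest size is the more cautious expectation. Compound 3 is expected to give 20000 nM in this assay, with a range from 5000 nM to 100000 nM, which means an expected step of a 2.2-fold higher number from compound 1 to compound 3 (0.35 log units; beyond the scatter).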

Compound 3, half-maximal inhibitory concentration: 32700 nM
Estimate against measurement, compound 3: 1.6-fold (0.21 log units) below; low and high end bracket the measured number.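

Replacing 4-fluorophenyl with ((4-methoxyphenyl)carbamoyl)methyl on the aromatic nitrogen gives a 3.7-fold higher number from compound 1 to compound 3 (0.57 log units; beyond the scatter) in this assay and so provides the first measured direction and size for a change at this position. The step is modest even though the entering group has 12 heavy atoms against 7 in the group that leaves, and it brings 1 hydrogen-bond donor and 2 hydrogen-bond acceptors where the leaving group has none. Nothing measured here bears on why the number rises with this change.

The change alters two things together, the carbamoylmethyl link between the triazole-type ring and the six-membered aromatic ring and the substituent on that ring, so the compounds shown leave open how much of the step belongs to each. They also leave open how a 4-methoxyphenyl group placed directly on the aromatic nitrogen, a 4-fluorophenyl group carried on the same carbamoylmethyl link, or a chain ending in an amine or a carboxylic acid would read in this assay at this position.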